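Nitro to Trifluoromethyl: One Change Tried on Two Cores

The source may report more compounds than this note shows. Statements on the series, on what has been measured and on what is new or still open speak of the compounds shown alone.

Measured so far in a functional assay on A549 cells (Homo sapiens) for inhibition, read by MTT assay, with a stated time of 72 h; a higher number here means a weaker inhibitor, a lower number a stronger inhibitor:
compound 1 `COc1cc(O)c(CC=C(C)C)c(O)c1C(=O)/C=C/c1ccc([N+](=O)[O-])cc1` gives 31200 nM
compound 2 `COc1cc(O)c(CC=C(C)C)c(O)c1C(=O)/C=C/c1ccc(C(F)(F)F)cc1` gives 11100 nM
compound 3 `COc1cc(OC)c(C(=O)/C=C/c2ccc([N+](=O)[O-])cc2)c(OC)c1` gives 7100 nM

Compound 2 differs from compound 1 by trifluoromethyl in place of nitro on an aromatic carbon, and this change gave a 2.8-fold lower number from compound 1 to compound 2 (0.45 log units; beyond the scatter). Compound 3 has a different core from compound 1; the difference between the two cores is not broken down here. In this assay compound 3 stands lowest of the three numbers, but its gap to compound 2 lies within the usual scatter, so the two cannot be ranked against each other. Compound 4 `COc1cc(OC)c(C(=O)/C=C/c2ccc(C(F)(F)F)cc2)c(OC)c1` has not yet been measured. It differs from compound 3 by trifluoromethyl in place of nitro on an aromatic carbon, the same change as before, at a place described in the same words. On these data alone, compound 4 is expected to be reached by a step of a 2.4-fold lower number from compound 3 to compound 4 (0.37 log units; beyond the scatter) because the same change gave a 2.8-fold lower number from compound 1 to compound 2 (0.45 log units; beyond the scatter) on the other core; whether it carries over unchanged is untested, so the range is kept wide. Compound 4 is therefore estimated at about 3000 nM, most likely between 1200 nM and 8000 nM.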

Compound 4, half-maximal inhibitory concentration: 14200 nM
For compound 4 the middle estimate is 4.7-fold (0.68 log units) below the measured one; measured number above the stated range.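

In this assay, moving the swap of nitro for trifluoromethyl onto the second core gave a 2.0-fold higher number from compound 3 to compound 4 (0.30 log units; within the scatter), so these two compounds cannot be ranked against each other. Set beside the first step, the result differs clearly between the two cores: the same change on two cores in this assay, a 2.8-fold lower number (0.45 log units; beyond the scatter) from compound 1 to compound 2 and a 2.0-fold higher number (0.30 log units; within the scatter) from compound 3 to compound 4, 5.6-fold (0.75 log units) apart, beyond the scatter of two such steps This shows that, in this series, the outcome of the swap on one core cannot simply be assumed on the other, although it does not show why the outcome differs, and with only two pairs it cannot show how the swap would behave on any further core.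

The compounds shown leave open which of the differences between the two cores matters for this result, since the cores differ in more than one place. They also leave open how other groups on the same aromatic carbon, such as an amine, a carboxylic acid or a nitrile, would behave on each core.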